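The source may hold more compounds than are shown below. What is called first, only, known or untested is meant among the compounds shown, and "the series" means these compounds.

Measured so far:
compound 1 `CCCCc1nc(=O)c(S(=O)(=O)c2ccc(-c3ccnc(NC(=O)C4CC4)c3)cc2)c(O)n1-c1c(OC)cccc1OC`: 72%
compound 2 `CCCCc1[nH]c(=O)c(S(=O)(=O)c2ccc(-c3ccc(F)nc3)cc2)c(O)c1-c1c(OC)cccc1OC`: "not determined" (no result reported)

Among the measured compounds shown here, in an ADME assay on microsomes from liver (Mus musculus) for metabolic stability, using NADPH, with a stated time of 10 min (a higher number here means that more of the compound is left, a lower number that less of the compound is left), compound 1 gives 72%, the only number so far, so its standing cannot be judged against any other compound. Compound 2 offers no comparison, with its entry reading "not determined" (no result reported).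

Compound 3 `CCCCc1nc(=O)c(S(=O)(=O)c2ccc(C3CC3)cc2)c(O)n1-c1c(OC)cccc1OC` differs from compound 1 at one place: cyclopropyl in place of 2-((cyclopropylcarbonyl)amino)pyridin-4-yl on an aromatic carbon. The exchange lies on an aromatic carbon of a six-membered aromatic ring of carbon only, para to a large group, and the rest of the structure stays the same.

For the measured compounds named here, no step between measured compounds is available to size this exchange. In this assay, the working expectation is therefore no step beyond the usual scatter, with no direction favoured. Going by the values given here, the only anchor is compound 1 at 72%, and a single anchor calls for a wide range. The estimated step is a number 2 percentage points lower from compound 1 to compound 3 (within the scatter). The expected value for compound 3 is 70%, with an estimated range of 45% to 90%.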

Compound 3, percent of the compound remaining: 93%
The estimate for compound 3 lay 23 percentage points below the measured number; measured number above the stated range.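

At the aromatic carbon para to a large group, the series now has its first readable step in this assay: cyclopropyl in place of 2-((cyclopropylcarbonyl)amino)pyridin-4-yl gives a number 21 percentage points higher from compound 1 to compound 3 (beyond the scatter). Among the compounds shown here, this shows that the read-out at this position depends on the group carried there, with the shared core unchanged, and that the smaller group of this pair is the one with more compound left. The exchange replaces the entire group in a single step, so the amide hydrogen, the carbonyl, the pyridine nitrogen and the outer cyclopropyl are not separated from one another, and no part of the leaving group can be tied to the difference; no supporting measurement bears on why the number moves.

Open, from the compounds shown here alone, is whether the step follows from loss of the whole 2-((cyclopropylcarbonyl)amino)pyridin-4-yl group or of only one part of it, which a plain pyridin-4-yl or a 2-aminopyridin-4-yl at the same place would help to separate. Also open, going by these compounds, is how far other small groups at this carbon, such as a methyl, a methoxy or a longer alkyl chain, would follow cyclopropyl.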